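The source may report more compounds than this note shows. Statements on the series, on what has been measured and on what is new or still open speak of the compounds shown alone.

Working notes on the series.

Compound 1 `Cc1ccccc1Nc1nnc(Nc2nc(-c3ccc(Cl)cc3)cs2)s1` and compound 2 `COc1ccccc1Nc1nnc(Nc2nc(-c3ccc(Cl)cc3)cs2)s1` share one core; compound 3 `Cc1ccc(Nc2nnc(Nc3nc(-c4ccc(Br)cc4)cs3)s2)cc1` and the as yet unmeasured compound 4 `COc1ccc(Nc2nnc(Nc3nc(-c4ccc(Br)cc4)cs3)s2)cc1` share another. How the two cores differ is not broken down here. In a functional assay on the whole organism (strain albino) with Mus musculus as the target, in the maximal electroshock model, with a stated time of 4 h (on this read-out higher numbers stand for an effect only at larger amounts of compound and lower numbers for an effect already at smaller amounts), compound 1 gives 300 mg/kg, and compound 2 gives 300 mg/kg; the step of no change at the digits printed from compound 1 to compound 2 (within the scatter) is methoxy in place of methyl on an aromatic carbon. In this assay compound 3 gives 100 mg/kg, the lowest of the three numbers, with both compound 1 and compound 2 beyond the scatter from it.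

The change from compound 3 to compound 4 is methoxy in place of methyl on an aromatic carbon. It is the same kind of change as that from compound 1 to compound 2, not the same: in compound 1 the group sits ortho to a large group, in compound 3 it sits para to a large group. The step from compound 3 to compound 4 is nevertheless expected to be no change at the digits printed from compound 3 to compound 4 (within the scatter), essentially flat, because no change at the digits printed from compound 1 to compound 2 (within the scatter) shows no change. For compound 4 the estimate in this assay is therefore 100 mg/kg, expected to fall between 50 mg/kg and 300 mg/kg.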

Compound 4, minimum effective dose: 100 mg/kg
Compound 4: middle estimate and measured number agree at the digits printed, within the range that was stated.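

In this assay, methoxy in place of methyl on an aromatic carbon gives no change at the digits printed from compound 3 to compound 4 (within the scatter), and the step on the other core reads the same: the same change on two cores in this assay, no change at the digits printed (within the scatter) from compound 1 to compound 2 and no change at the digits printed (within the scatter) from compound 3 to compound 4, 1.0-fold (0.00 log units) apart, within the scatter of two such steps. On these two cores, then, the change carries over with the same flat outcome, here with the group para to a large group on the core of compound 4. This rests on two pairs only, and both steps are flat, so it shows agreement in the absence of a shift and does not show that a step of real size would carry from one core to the other in the same way.

The compounds shown leave open whether an amine, a carboxylic acid or a longer chain such as ethoxy in the same place would move the minimum effective dose. They also leave open whether the swap of methyl for methoxy stays flat on any core beyond these two.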